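Halogen swap on a thiosemicarbazone-bearing isatin-quinoline hybrid

A few compounds are considered here, and "the series" means these few. Any claim that something is new, unique, unknown or untested is made for them only; others in the source may bear on it.

Measured compounds:
compound 1, `O=C1C(=O)N(CN2CCN(c3ccnc4cc(Cl)ccc34)CC2)c2cccc(Cl)c21`, 77700 nM
compound 2, `O=C1C(=O)N(CN2CCN(c3ccnc4cc(Cl)ccc34)CC2)c2cccc(Br)c21`, 49000 nM
compound 3, `NC(=S)N/N=C1/C(=O)N(CN2CCN(c3ccnc4cc(Cl)ccc34)CC2)c2cccc(Cl)c21`, 20700 nM

In an ADME assay on 184B5 cells (Homo sapiens) for cytotoxicity, read by sulforhodamine B assay, with a stated time of 48 h (on this read-out higher numbers stand for weaker inhibition of growth and lower numbers for stronger inhibition of growth), compound 1 gives 77700 nM and compound 2 gives 49000 nM. The two differ only by bromo in place of chloro on an aromatic carbon, and the step of a 1.6-fold lower number from compound 1 to compound 2 (0.20 log units; within the scatter). Compound 3, built on a different core, gives 20700 nM in this assay, the lowest of the three numbers; how its core differs from that of compound 1 is not broken down here. Compound 4, `NC(=S)N/N=C1/C(=O)N(CN2CCN(c3ccnc4cc(Cl)ccc34)CC2)c2cccc(Br)c21`, has not yet been measured. It differs from compound 3 by bromo in place of chloro on an aromatic carbon, the same change, at the same place, that separates compound 1 from compound 2. That change occurs twice among these compounds and in its one measured instance stayed within the scatter. Compound 4 is therefore expected to give 14000 nM in this assay, with a 1.5-fold lower number from compound 3 to compound 4 (0.17 log units; within the scatter), because the earlier step of a 1.6-fold lower number from compound 1 to compound 2 (0.20 log units; within the scatter) was small and the core of compound 3 is carried over unchanged. The expected range for compound 4 runs from 6000 nM to 32000 nM.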

Compound 4, concentration for 50% growth inhibition: 46400 nM
Compound 4: middle estimate off by 3.3-fold (0.52 log units), on the low side; measured number outside the range, above it.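

On the core of compound 3, bromo in place of chloro on an aromatic carbon gives a 2.2-fold higher number from compound 3 to compound 4 (0.35 log units; beyond the scatter) in this assay. Set beside the earlier step, this shows that the change does not carry over with the same outcome between these two cores: the same change on two cores in this assay, a 1.6-fold lower number (0.20 log units; within the scatter) from compound 1 to compound 2 and a 2.2-fold higher number (0.35 log units; beyond the scatter) from compound 3 to compound 4, 3.6-fold (0.55 log units) apart, beyond the scatter of two such steps

The comparison rests on a single pair per core and on one read-out, so it shows that the outcome of this swap differed between the two cores here, but it does not show why, and it gives no rule for any other core or assay.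

The compounds shown carry only chloro and bromo at this place, so it remains open how fluoro, methyl or methoxy there would behave on either core. Going by these compounds, it also remains open whether a similar gap between the steps would appear on a core carrying a semicarbazone or an oxime in place of the thiosemicarbazone.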